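This account rests on a few compounds, and the source may have more. Where it says the series, first, only, none or still open, it means among the compounds named here.

Measured so far:
compound 1 `O=c1c(CCO)c(-c2ccccc2Cl)c2cc(Cl)ccc2n1-c1ccccc1`: 26000 nM
compound 2 `CC12CCC(C(=O)OCCc3c(-c4ccccc4Cl)c4cc(Cl)ccc4[nH]c3=O)(OC1=O)C2(C)C`: > 1800000 nM

The read-out is an ADME assay on HepG2 2.2.15 cells (Homo sapiens) for cytotoxicity; a lower number here means that less compound is tolerated, a higher number that more compound is tolerated. Compound 1 gives 26000 nM in this assay. For compound 2 the result is a limit and not a number: > 1800000 nM. This places compound 2 at the limit of > 1800000 nM in this assay, at which 1 of the 2 values shown sits, the upper edge of what this assay reports, so its separation from compound 1 can only be stated as reaching that edge, not as a counted step.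

Compound 3 `COc1ccc(/C=C/C(=O)OCCc2c(-c3ccccc3Cl)c3cc(Cl)ccc3[nH]c2=O)cc1` has not yet been measured in this assay. Compared with compound 2 it differs in one place: a group of 10 heavy atoms (9 carbon, 1 oxygen; one six-membered aromatic ring of carbon only) in place of a group of 11 heavy atoms (9 carbon, 2 oxygen; one five-membered non-aromatic ring of carbon only, one five-membered non-aromatic ring with 1 hetero atom), on a carbonyl carbon. The exchanged group sits on a carbonyl carbon whose other neighbour is an oxygen next to a carbonyl group, and both compounds share the rest of the core. Going by the values given here, no step between two measured compounds is available to size this kind of change, and compound 2 itself only reaches the limit. The step expected is an at least 4.5-fold lower number from compound 2 to compound 3 (0.65 log units; beyond the scatter), most likely a modest fall beyond the scatter, since the limit of compound 2 leaves room below it. Compound 3 is therefore estimated at 400000 nM, with a range from 80000 nM to 1800000 nM.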

Compound 3, half-maximal cytotoxic concentration: > 1200000 nM
Compound 3 ended at the assay's limit; the forecaster's own chance of this, stated with the estimate: 40%; at least 3.0-fold (0.47 log units) between middle value and limit.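

Going by these compounds alone, compound 2 and compound 3 both stand as limits and not as numbers in this assay, and no step between them can be read. The compounds shown leave open whether placing 2-(4-methoxyphenyl)ethenyl on the carbonyl carbon, in exchange for the group in compound 2, changes the tolerated concentration at all, and in which direction.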